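The compounds below may be only part of what the source reports. "The series", "measured", "known", "first", "only" and "open" are said of these compounds alone.

Measured in a functional assay on MCF7 cells (Homo sapiens) for inhibition, read by sulforhodamine B assay, with a stated time of 48 h; a lower number here means a stronger inhibitor, a higher number a weaker inhibitor:

Compound 1 `COc1ccc(C(c2ccc(OC(C)CN(C)C)cc2)c2cccc3ccccc23)c(OC)c1OC`: 13100 nM
Compound 2 `C=CCC(O)(c1ccc(OC)c(OC)c1OC)c1cccc2ccccc12`: > 20000 nM (a limit of the assay, not a number)

Among the compounds with values here, compound 1 carries the only actual number in this assay, since the reading for compound 2 is just a limit. Compound 3 `COc1ccc(C(c2ccc(OCCO)cc2)c2cccc3ccccc23)c(OC)c1OC` keeps the core of compound 1 and changes one group: 2-hydroxyethyl in place of 1-((dimethylamino)methyl)ethyl on an oxygen on an aromatic ring. Within the data shown here, no measured step between two compounds speaks to this change, so the expectation starts only from compound 1 at 13100 nM. A modest shift towards weaker inhibition seems most likely, and a reading that is only a limit would be no surprise. The expected change is a 1.3-fold higher number from compound 1 to compound 3 (0.11 log units; within the scatter). Compound 3 is estimated at 17000 nM, with an expected range of 6000 nM to 40000 nM.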

Compound 3, half-maximal inhibitory concentration: > 20000 nM
Compound 3: only a limit was reported; the forecaster's own chance of this, stated with the estimate: 35%; middle value at least 1.1-fold (0.07 log units) away from the limit.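

In this assay compound 3 gives > 20000 nM as a limit of the assay and not a number. Putting 2-hydroxyethyl in place of 1-((dimethylamino)methyl)ethyl on an oxygen on an aromatic ring reads as an at least 1.5-fold higher number from compound 1 to compound 3 (0.18 log units; that floor lies within the scatter) and no more than that, so this change is not shown to weaken inhibition, and the true size of the step stays unknown. What the result adds is that a second substituent on this oxygen yields no number, and the reading stops at the same ceiling as the other limit: the limit of > 20000 nM in this assay, at which 2 of the 3 values shown sit.

The compounds shown do not separate the loss of the dimethylamino nitrogen from the shorter chain. A 2-(dimethylamino)ethyl group on the same oxygen would speak to that, and a carboxylic acid there remains an open case.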